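The source may hold more compounds than are shown below. What is called first, only, known or untested is meant among the compounds shown, and "the series" means these compounds.

Measured so far:
- compound 1 `C=CC1C(=O)N(c2cc(OC)c(OC)c(OC)c2)C1c1ccc(OC)cc1` gives 17 nM in a functional assay on MCF7 cells (Homo sapiens) for inhibition, read by resazurin assay, with a stated time of 72 h; on this read-out higher numbers stand for weaker inhibition and lower numbers for stronger inhibition
- compound 2 `CCOc1ccc(C2C(C3CC3)C(=O)N2c2cc(OC)c(OC)c(OC)c2)cc1` gives 131 nM
- compound 3 `COc1ccc(C2C(O)C(=O)N2c2cc(OC)c(OC)c(OC)c2)cc1` gives 4 nM

Compound 2 stands highest of the three; its nearest neighbour is compound 1 and its furthest compound 3, both beyond the scatter. Compound 4 `CCOc1ccc(C2C(Oc3ccccc3)C(=O)N2c2cc(OC)c(OC)c(OC)c2)cc1` is not yet measured. Change from compound 2: phenoxy in place of cyclopropyl on a saturated ring carbon. Among the measured compounds shown here, no measured step swaps these two groups. For the measured compounds named here, the only step at this ring carbon is a 4.3-fold lower number from compound 1 to compound 3 (0.63 log units; beyond the scatter), where an oxygen-bearing group replaced a carbon one and the number fell. Taken loosely, an oxygen-linked group entering here may again lower the number, though phenoxy is much larger than hydroxy, so the step is expected small to modest downward, as a 1.6-fold lower number from compound 2 to compound 4 (0.21 log units; within the scatter). Compound 4 is estimated at 80 nM, range 20 nM to 400 nM.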

Compound 4, half-maximal inhibitory concentration: 69 nM
Beside the measured number, compound 4's estimate is 1.2-fold (0.06 log units) above it, within the range that was stated.
By their numbers in this assay, from the lowest: compound 3; then compound 1; then compounds 4 and 2 (each within the scatter of the next).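

In this assay, phenoxy in place of cyclopropyl on this saturated ring carbon gives a 1.9-fold lower number from compound 2 to compound 4 (0.28 log units; within the scatter), so the two groups cannot be told apart here, although phenoxy brings 7 heavy atoms against 3 and an aromatic ring. The earlier step at this carbon, a 4.3-fold lower number from compound 1 to compound 3 (0.63 log units; beyond the scatter), lay beyond the scatter; this one does not.

Open, from the compounds shown here alone, is whether an amine, a carboxylic acid or a longer chain on this carbon would read like phenoxy, and how hydroxy would read alongside the 4-ethoxyphenyl group. No available evidence bears on this result.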